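The source may report more compounds than this note shows. Statements on the series, on what has been measured and on what is new or still open speak of the compounds shown alone.

In a functional assay on MCF7 cells (Homo sapiens) for cytotoxicity, read by MTT assay, with a stated time of 72 h (a lower number here means a stronger inhibitor, a higher number a weaker inhibitor), compound 1 `O=C1c2c[n+]([O-])c3ccccc3c2C(=O)c2c1c1ccccc1n2Cc1cn(C[C@H](O)CO)nn1` gives > 1000 nM as a limit and not a number. Within the data shown here, compound 2 `O=C1c2c[n+]([O-])c3ccccc3c2C(=O)c2c1c1ccccc1n2CCCCN1CCNCC1` gives 12000 nM in this assay and holds the only true number available. Compound 3 `O=C1c2c[n+]([O-])c3ccccc3c2C(=O)c2c1c1ccccc1n2CCCCN1CCCCC1` differs from it as follows: piperidin-1-yl in place of piperazin-1-yl on a saturated chain carbon, four bonds along the chain from an aromatic nitrogen on the same chain. Among the measured compounds shown here, the one measured step that the limit leaves unreadable from compound 1 to compound 2 has no readable size and concerns a different group, so it offers no guide to this change. No shift beyond the scatter is therefore expected in this assay and no direction is favoured. The expected step is a 1.2-fold lower number from compound 2 to compound 3 (0.08 log units; within the scatter) on this estimate. For compound 3 the estimated value is 10000 nM with an expected range of 3000 nM to 30000 nM in this assay.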

Compound 3, half-maximal inhibitory concentration: 150 nM
The estimate for compound 3 lay 67-fold (1.82 log units) above the measured number; the measured number lies below the stated range.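

In this assay the exchange of piperazin-1-yl for piperidin-1-yl, with the chain unchanged, gives an 80-fold lower number from compound 2 to compound 3 (1.90 log units; beyond the scatter) and so shows that the amine ring at the end of this chain matters greatly. Compound 3 also shows an at least 6.6-fold lower number from compound 1 to compound 3 (0.82 log units; beyond the scatter) as a step that rests on the limit held by compound 1, which is not a number. Nothing given here explains the size of these steps.

The compounds shown leave open whether a morpholine ring or an open dimethylamino group at the chain end would keep this level, and whether a shorter or longer chain would.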